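This account rests on a few compounds, and the source may have more. Where it says the series, first, only, none or still open, it means among the compounds named here.

In a functional assay on a cell-free system (plasma) for inhibition of thromboxane A2 receptor (Homo sapiens), read by turbidimetry (on this read-out higher numbers stand for weaker inhibition and lower numbers for stronger inhibition), compound 3 `O=C(O)CCCCCC[C@H]1[C@H](F)CC[C@@H]1NS(=O)(=O)c1ccc(F)cc1` gives 2400 nM, the highest of the three numbers shown, although compound 1 `O=C(O)COCCCC[C@H]1[C@H](F)CC[C@@H]1NS(=O)(=O)c1ccc(F)cc1` with 1800 nM and compound 2 `O=C(O)CC/C=C\C[C@H]1[C@H](F)CC[C@@H]1NS(=O)(=O)c1ccc(Cl)c(Cl)c1` with 1700 nM both lie within the scatter of it. Compound 4 `O=C(O)CC/C=C\C[C@H]1[C@H](F)CC[C@@H]1NS(=O)(=O)c1ccc(F)cc1` differs from compound 3 by 4-carboxybut-1-en-1-yl in place of 5-carboxypentyl on a saturated chain carbon bound to a saturated ring carbon. Within the data shown here, the only measured step that alters the chain is a 1.3-fold higher number from compound 1 to compound 3 (0.12 log units; within the scatter), which changes the chain at a different point and stays within the scatter. Compound 2 carries the same unsaturated chain as compound 4 on a different aryl group, and its value sits close to that of compound 3. No step beyond the scatter is therefore expected in this assay. The change is estimated as a 1.3-fold lower number from compound 3 to compound 4 (0.12 log units; within the scatter). Compound 4 is expected at 1800 nM, with a range from 900 nM to 3600 nM.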

Compound 4, half-maximal inhibitory concentration: 750 nM
Compound 4: the middle estimate sits 2.4-fold (0.38 log units) above what was measured, outside the stated range (below it).
By their numbers in this assay, from the lowest: compound 4; then compounds 2, 1 and 3 (each within the scatter of the next).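

In this assay the group on the saturated chain carbon bound to a saturated ring carbon now makes a difference beyond the scatter: 4-carboxybut-1-en-1-yl in place of 5-carboxypentyl gives a 3.2-fold lower number from compound 3 to compound 4 (0.51 log units; beyond the scatter) and in place of 3-(carboxymethoxy)propyl gives a 2.4-fold lower number from compound 1 to compound 4 (0.38 log units; beyond the scatter) while the earlier chain step stayed within the scatter. With this chain held fixed, the group on the sulfonyl sulfur also matters: 4-fluorophenyl in place of 3,4-dichlorophenyl gives a 2.3-fold lower number from compound 2 to compound 4 (0.36 log units; beyond the scatter) on the same read-out. Nothing available accounts for these steps.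

The compounds shown leave open whether a tetrazole can stand in for the carboxylic acid on the 4-carboxybut-1-en-1-yl chain. They also leave open how a longer unsaturated chain, or a 4-methoxyphenyl group on the sulfonyl sulfur, would read.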